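The source may hold more compounds than are shown below. What is called first, only, known or untested is meant among the compounds shown, and "the series" means these compounds.

Measured so far:
- compound 1, `CC(=O)OCCCc1ccc(O)c(O)c1`: 83000 nM
- compound 2, `CCC(OC(C)=O)c1ccc(OC(C)=O)c(OC(C)=O)c1`: 42000 nM

Both values come from a functional assay on PC-3 cells (Homo sapiens) for inhibition, read by MTT assay, with a stated time of 48 h (on this read-out lower numbers stand for stronger inhibition and higher numbers for weaker inhibition), and the two numbers lie within the usual scatter of each other, so compound 2 and compound 1 cannot be told apart on this read-out. Compound 3, `CCC(OC(C)=O)c1ccc(O)c(OC(C)=O)c1`, differs from compound 2 by hydrogen in place of acetyl on an oxygen on an aromatic ring. Among the measured compounds shown here, no measured pair shows this kind of change, so no firm guide exists. Compound 1, which carries two free hydroxy groups, and compound 2, which carries none, sit within the scatter of each other, so a step of a 1.2-fold higher number from compound 2 to compound 3 (0.08 log units; within the scatter) is expected, with no change beyond the scatter. Compound 3 is therefore estimated at 50000 nM, between 20000 nM and 130000 nM.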

Compound 3, half-maximal inhibitory concentration: 48000 nM
Estimate against measurement, compound 3: 1.0-fold (0.02 log units) above; low and high end bracket the measured number.
By their numbers in this assay, from the lowest: compounds 2, 3 and 1 (each within the scatter of the next).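

The first direct test of this change comes out flat: in this assay, hydrogen in place of acetyl on an oxygen on an aromatic ring gives a 1.1-fold higher number from compound 2 to compound 3 (0.06 log units; within the scatter) and nothing that stands clear of the scatter. At this position, acetoxy and hydroxy therefore cannot be told apart on this read-out. Nothing available gives a reason for this result.

Still open, on these data alone, is whether the same swap on the other aromatic oxygen would also leave the number unchanged. Also open, as far as these compounds go, is whether a methyl group or a longer acyl chain on this oxygen, or an amine in place of the hydroxy, would move the number beyond the scatter.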